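The source may report more compounds than this note shows. Statements on the series, on what has been measured and on what is new or still open speak of the compounds shown alone.

Series notes. In a functional assay on K562 cells (Homo sapiens), read by MTT assay, with a stated time of 72 h (a higher number here means a weaker inhibitor, a lower number a stronger inhibitor), compound 1 `COc1nc(N)nc2c1c(-c1cc3ccccc3o1)cn2[C@@H]1O[C@H](CO)[C@@H](O)[C@H]1O` gives 14600 nM, the lowest of the three numbers in hand. Compound 2 `Nc1nc(N)c2c(-c3cc4ccccc4o3)cn([C@@H]3O[C@H](CO)[C@@H](O)[C@H]3O)c2n1` gives 18600 nM and compound 3 `COc1ncnc2c1c(-c1cc3ccccc3o1)cn2[C@@H]1O[C@H](CO)[C@@H](O)[C@H]1O` gives 20900 nM; the steps of a 1.3-fold higher number from compound 1 to compound 2 (0.11 log units; within the scatter) and a 1.4-fold higher number from compound 1 to compound 3 (0.16 log units; within the scatter) both stay within the scatter, so the three compounds sit at one level. Compound 4 `C#Cc1cn([C@@H]2O[C@H](CO)[C@@H](O)[C@H]2O)c2nc(N)nc(OC)c12` is not yet measured; its change from compound 1 is ethynyl in place of 1-benzofuran-2-yl on an aromatic carbon. Neither measured step touches this position, and both concern small exchanges on the shared core, so they give no guide to the size of this step. Removing the 1-benzofuran-2-yl group for ethynyl is a larger change than anything measured here, and a weaker number is expected, estimated as a 3.1-fold higher number from compound 1 to compound 4 (0.49 log units; beyond the scatter). Compound 4 is therefore estimated at 45000 nM, with a range from 9000 nM to 200000 nM.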

Compound 4, half-maximal inhibitory concentration: > 20000 nM
Compound 4 ended at the assay's limit; the forecaster's own chance of this, stated with the estimate: 30%; the middle value does not contradict the limit.
By their numbers in this assay, from the lowest: compounds 1, 2 and 3 (each within the scatter of the next).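

In this assay compound 4 gives > 20000 nM, which is a limit of the assay and not a number. Among these compounds, this is the first change at this aromatic carbon of the five-membered ring, and it can be read only as an at least 1.3-fold higher number from compound 1 to compound 4 (0.13 log units; that floor lies within the scatter), so ethynyl in place of 1-benzofuran-2-yl gives no number below the limit, but the size of the step stays unresolved. Compound 4 is the only compound at that limit: the limit of > 20000 nM in this assay, at which 1 of the 4 values shown sits.

Going by these compounds, how far compound 4 lies past the limit remains open. Also open, on these data alone, is whether a single phenyl ring or a longer alkyne chain on this carbon would give a readable number.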